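A Methyl on the Aryl Ring of Compound 1

A few compounds are considered here, and "the series" means these few. Any claim that something is new, unique, unknown or untested is made for them only; others in the source may bear on it.

Compound 1, `Cc1ccc(N2CCN(CCNC(=O)c3cccnc3)CC2)cc1`: 295 nM
Compound 2, `Cc1ccc(N2CCN(CCNC(=O)c3ccncc3)CC2)cc1`: 316 nM
Compound 3, `Cc1ccc(N2CCN(CCNC(=O)c3cc4ccccc4o3)CC2)cc1`: 120 nM

In a functional assay for antagonist activity at Adrenergic receptor alpha-1 (Rattus norvegicus) (on this read-out higher numbers stand for weaker binding and lower numbers for tighter binding), compound 1 gives 295 nM, the second highest of the three numbers. Its nearest neighbour is compound 2, which gives 316 nM; the step of a 1.1-fold higher number from compound 1 to compound 2 (0.03 log units; within the scatter) stays within the scatter, so the two cannot be ordered. The furthest is compound 3, which gives 120 nM; the step of a 2.5-fold lower number from compound 1 to compound 3 (0.39 log units; beyond the scatter) is modest but beyond the scatter, as is a 2.6-fold lower number from compound 2 to compound 3 (0.42 log units; beyond the scatter).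

Compound 4, `Cc1ccc(N2CCN(CCNC(=O)c3cccnc3)CC2)c(C)c1`, differs from compound 1 by methyl in place of hydrogen on an aromatic carbon. All three measured steps concern the group on the carbonyl carbon at the other end of the shared core; none of them touches the aryl ring where the new methyl enters. Among the measured compounds shown here, no measured step therefore bears on this change, and there is nothing in these data to suggest a shift in one direction or the other. On that basis compound 4 is expected to sit close to compound 1, with a step of no change at the digits printed from compound 1 to compound 4 (within the scatter) that is estimated to lie within the scatter. As far as these compounds go, the estimate for compound 4 in this assay is 295 nM, in a range from 100 nM to 900 nM, kept wide since the change is untested here.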

Compound 4, dissociation constant: 1150 nM
Compound 4: middle estimate off by 3.9-fold (0.59 log units), on the low side; the measured number lies above the stated range.
By their numbers in this assay, from the lowest: compound 3; then compounds 1 and 2 (each within the scatter of the next); then compound 4.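

Among the compounds shown here, the aryl ring, which none of the earlier steps touched, proves not to be a silent part of the shared core. In this assay, changing 4-methylphenyl to 2,4-dimethylphenyl gives a 3.9-fold higher number from compound 1 to compound 4 (0.59 log units; beyond the scatter) and so moves the read-out toward weaker binding, which shows that a single methyl on an aromatic carbon, ortho to a large group, can matter here. The earlier compounds had shown change only at the carbonyl end, and only in the direction of tighter binding, with a 2.5-fold lower number from compound 1 to compound 3 (0.39 log units; beyond the scatter) as the example, whereas this new step of modest size runs the opposite way; nothing available explains the shift.

The compounds shown leave open whether the same methyl would raise the number as well with pyridin-4-yl or 1-benzofuran-2-yl on the carbonyl carbon, since here it appears only with pyridin-3-yl. They also leave open whether the shift belongs to methyl in particular or would also follow from another group in its place, such as a chlorine atom, a methoxy group or an amine.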